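Working notes on the 4-methoxyphenyl replacement

This account rests on a few compounds, and the source may have more. Where it says the series, first, only, none or still open, it means among the compounds named here.

Measured so far:
compound 1 `COc1ccc(-c2ccc(C(O)Cc3cc(OC)c(OC)cc3[N+](=O)[O-])cc2)cc1` gives > 244000 nM in an ADME assay on HeLa Rh cells (Homo sapiens) for cytotoxicity, read by microscopy; a lower number here means that less compound is tolerated, a higher number that more compound is tolerated
compound 2 `COc1cc(CC(O)c2ccc(-c3cccc(C#N)c3)cc2)c([N+](=O)[O-])cc1OC` gives 5200 nM in this assay

For compound 1 the value is a limit of the assay and not a number (the limit of > 244000 nM in this assay, at which 1 of the 2 values shown sits). Compound 2 carries 3-cyanophenyl where compound 1 carries 4-methoxyphenyl, and the measured step is an at least 46-fold lower number from compound 1 to compound 2 (1.67 log units; beyond the scatter). Compound 3 `COc1cc(CC(O)c2ccc(-c3cccs3)cc2)c([N+](=O)[O-])cc1OC` has not yet been measured in this assay. It differs from compound 1 in one place: thiophen-2-yl in place of 4-methoxyphenyl on an aromatic carbon. Among the measured compounds shown here, the only measured step that bears on it is the step from compound 1 to compound 2, which also replaces the 4-methoxyphenyl group and was large. A step in the same direction, toward a lower number, is therefore expected, though its size cannot be read from a single step to a different group. Compound 3 is expected to give 40000 nM in this assay, within 8000 nM to 244000 nM. That estimate means an expected step of an at least 6.1-fold lower number from compound 1 to compound 3 (0.78 log units; beyond the scatter).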

Compound 3, half-maximal cytotoxic concentration: 11000 nM
For compound 3 the middle estimate is 3.6-fold (0.56 log units) above the measured one, and the stated range covers the measured number.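

In this assay, thiophen-2-yl in place of 4-methoxyphenyl gives an at least 22-fold lower number from compound 1 to compound 3 (1.34 log units; beyond the scatter), so a large step at this position is not confined to 3-cyanophenyl. Exchanging the two replacement groups gives a 2.1-fold higher number from compound 2 to compound 3 (0.33 log units; beyond the scatter), a much smaller change than leaving 4-methoxyphenyl for either of them. The value of compound 1 is a limit of the assay and not a number: the limit of > 244000 nM in this assay, at which 1 of the 3 values shown sits.

The compounds shown leave open whether the lower numbers follow from the loss of the methoxy group or from the change of the whole aryl group. From the compounds shown here alone, an unsubstituted phenyl group or a 4-aminophenyl group at this position could separate these two readings, and the core of compound 1 stays unexplored beyond this one position.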